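This account rests on a few compounds, and the source may have more. Where it says the series, first, only, none or still open, it means among the compounds named here.

Of the compounds shown here, three built on related cores have been tested in an ADME assay on Vero cells (Chlorocebus sabaeus) for cytotoxicity, with a stated time of 72 h, tested at 50 ug/mL; on this read-out lower numbers stand for a weaker effect and higher numbers for a stronger effect at the one concentration tested. Compound 1 `O=c1[nH]nc2n(c1=O)CCN2c1ccccc1` gives 30%. Compound 2 `N=c1c(=O)[nH]nc2n1CCN2c1ccccc1` gives 30% in this assay; the difference between the two cores is not broken down here, so their values can only be set side by side, and they are level at the digits reported. Compound 3 `O=c1[nH]nc2n(c1=O)CCN2c1cccc(Cl)c1` gives 24%. Relative to compound 1 it carries chloro in place of hydrogen on an aromatic carbon, and that step is a number 6 percentage points lower from compound 1 to compound 3 (within the scatter).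

Compound 4 `N=c1c(=O)[nH]nc2n1CCN2c1ccc(Cl)cc1` has not yet been measured in this assay. Relative to compound 2 it carries chloro in place of hydrogen on an aromatic carbon. This is the same kind of change as from compound 1 to compound 3, but not the same change, since in compound 3 the chloro sits meta to a large group while in compound 4 it sits para to a large group. Among the measured compounds shown here, because compound 2 stands at 30% and the one measured example of this kind of change is a number 6 percentage points lower from compound 1 to compound 3 (within the scatter), a step of similarly small size is expected for compound 4. The expected step is a number 5 percentage points lower from compound 2 to compound 4 (within the scatter). Compound 4 is therefore estimated at 25%, with the result expected to fall between 12% and 38%.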

Compound 4, a percentage reported as inhibition, at one concentration (the size of the read-out at that concentration, not a potency): 0%
For compound 4 the middle estimate is 25 percentage points above the measured one; the measured number lies below the stated range.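

In this assay, putting chloro in place of hydrogen on an aromatic carbon of the second core gives a number 30 percentage points lower from compound 2 to compound 4 (beyond the scatter). Among the compounds shown here, the size of a chloro step read on one core therefore cannot simply be carried over to the other core, as the two steps set side by side show: the same change on two cores in this assay, a number 6 percentage points lower (within the scatter) from compound 1 to compound 3 and a number 30 percentage points lower (beyond the scatter) from compound 2 to compound 4, 24 percentage points apart, beyond the scatter of two such steps What this does not show is whether the core itself sets the size of the step, as the chloro stands para to a large group in compound 4 and at a different place on the ring in compound 3, so core and chloro position change together and each core offers only one step.

The compounds shown leave open what a chloro at the same ring position would do on both cores, which is the comparison that would separate these two differences. They also leave open whether other groups on the aromatic ring, such as a methoxy group, an amine or a carboxylic acid, would differ between the cores in the same way.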